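Bromo in Place of Methoxy on the Aryl Ring

A few compounds are considered here, and "the series" means these few. Any claim that something is new, unique, unknown or untested is made for them only; others in the source may bear on it.

In a functional assay on cells (Splenocyte, Mus musculus, strain BALB/c) for inhibition, read by scintillation counting and thymidine incorporation, with stated times of 48 h and 8 h (on this read-out lower numbers stand for stronger inhibition and higher numbers for weaker inhibition), compound 2 `COc1ccc(OC)c(-c2nc(Cc3c[nH]c4ccccc34)no2)c1` gives 8400 nM and compound 1 `COc1cccc(-c2nc(Cc3c[nH]c4ccccc34)no2)c1` gives 11100 nM, two numbers that lie within the scatter of each other, so compound 2 stands alongside compound 1 rather than apart from it. Compound 3 `COc1ccc(Br)c(-c2nc(Cc3c[nH]c4ccccc34)no2)c1` differs from compound 2 by bromo in place of methoxy on an aromatic carbon. Among the measured compounds shown here, no measured step covers this exchange; the only step in hand, a 1.3-fold lower number from compound 1 to compound 2 (0.12 log units; within the scatter), was within the scatter, so no shift beyond the scatter is expected for compound 3, a 1.1-fold higher number from compound 2 to compound 3 (0.03 log units; within the scatter). The estimate for compound 3 is 9000 nM, expected between 4000 nM and 20000 nM.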

Compound 3, half-maximal inhibitory concentration: 6900 nM
Beside the measured number, compound 3's estimate is 1.3-fold (0.12 log units) above it, within the range that was stated.
By their numbers in this assay, from the lowest: compounds 3, 2 and 1 (each within the scatter of the next).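

In this assay, bromo takes the place of methoxy on the aromatic carbon ortho to a large group and para to a methoxy group with a 1.2-fold lower number from compound 2 to compound 3 (0.09 log units; within the scatter) and takes the place of hydrogen there with a 1.6-fold lower number from compound 1 to compound 3 (0.21 log units; within the scatter) as the second reading. This position has therefore carried hydrogen, methoxy and bromo with no step beyond the scatter, so the change from methoxy to bromo does not set compound 3 apart from compound 2 or compound 1. Nothing at hand explains these numbers.

Going by these compounds, whether an amine or a carboxylic acid at this position would give a step beyond the scatter remains open. So does the outcome for a longer chain there.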